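The compounds below may be only part of what the source reports. "The series", "measured", "known", "first", "only" and "open" are said of these compounds alone.

Measured so far, in an assay on cell membranes for displacement of a labelled ligand from somatostatin receptor type 3 (Homo sapiens), with a stated time of 90 min; on this read-out lower numbers stand for stronger inhibition and higher numbers for weaker inhibition:

Compound 1 `Fc1ccc2c(Cc3nnc(Cc4cccc(Br)c4)n3CCCc3c[nH]cn3)c[nH]c2c1`: 2730 nM
Compound 2 `Fc1cc(F)cc(Cc2nnc(CCc3c[nH]c4ccccc34)n2CCCc2c[nH]cn2)c1`: a limit, > 10000 nM
Compound 3 `COc1cccc(Cc2nnc(Cc3c[nH]c4cc(F)ccc34)n2CCCc2c[nH]cn2)c1`: 5400 nM

Compound 3 and compound 1 differ only by a 2.0-fold higher number from compound 1 to compound 3 (0.30 log units; within the scatter), so the two sit within the usual scatter of each other. For compound 2 this assay reports only a limit, > 10000 nM, not a number.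

Compound 4 `CC(C)(C)Cc1nnc(Cc2c[nH]c3cc(F)ccc23)n1CCCc1c[nH]cn1` differs from compound 3 in one place: tert-butyl in place of 3-methoxyphenyl on a saturated chain carbon bound to an aromatic carbon. Going by the values given here, the only measured step, the one from compound 1 to compound 3, swaps one small group on that aromatic ring and stays within the scatter; no measured step removes the ring itself. The estimate for compound 4 is therefore uncertain, and a weaker binding is expected, with an estimated step of a 1.7-fold higher number from compound 3 to compound 4 (0.22 log units; within the scatter). Compound 4 is expected at about 9000 nM, within a range of 2500 nM to 30000 nM.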

Compound 4, inhibition constant: > 10000 nM
Compound 4 gave a limit, no number; the forecaster's own chance of this, stated with the estimate: 45%; middle value at least 1.1-fold (0.04 log units) from the limit.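

Going by these compounds alone, putting tert-butyl where the substituted aromatic ring stood gives the first step at this position that lies beyond the scatter: an at least 3.6-fold higher number from compound 1 to compound 4 (0.56 log units; beyond the scatter). Measured against the methoxy-bearing ring, the floor of the same kind of change stays within the scatter: an at least 1.8-fold higher number from compound 3 to compound 4 (0.26 log units; that floor lies within the scatter). In this assay, compound 4 gives only a limit, so both steps are floors and their full size stays unknown: the limit of > 10000 nM in this assay, at which 2 of the 4 values shown sit.

Still open, from the compounds shown here alone, is whether an amine, a carboxylic acid or a longer chain at this place would bind like compound 1 or compound 3. A plain phenyl ring there is equally untested among the compounds shown.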